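Amino for hydrogen on the core of compound 1

This account rests on a few compounds, and the source may have more. Where it says the series, first, only, none or still open, it means among the compounds named here.

Measured in a functional assay on TK-10 cells (Homo sapiens) for cytotoxicity, read by sulforhodamine B assay, with a stated time of 48 h; a lower number here means a stronger inhibitor of growth, a higher number a weaker inhibitor of growth:
compound 1 `ClCc1ccc(Cn2cnc3c(Cl)ncnc32)cc1` gives 1090 nM
compound 2 `ClCc1ccccc1Cn1cnc2c(Cl)nc(Cl)nc21` gives 1450 nM

Compound 1 and compound 2 give numbers that lie within the scatter of each other in this assay, so neither stands apart. Compound 3 `Nc1nc(Cl)c2ncn(Cc3ccc(CCl)cc3)c2n1` differs from compound 1 by amino in place of hydrogen on an aromatic carbon. Among the compounds with values here, no pair of measured compounds shows this change, so no measured step sizes it. The change is expected to shift the number in this assay at most modestly, in either direction, not beyond the scatter. The step is expected to be a 1.2-fold lower number from compound 1 to compound 3 (0.08 log units; within the scatter). Compound 3 is estimated at 900 nM, with a range from 400 nM to 2200 nM.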

Compound 3, concentration for 50% growth inhibition: 16600 nM
Estimate against measurement, compound 3: 18-fold (1.27 log units) below; the whole stated range lies below it.
By their numbers in this assay, from the lowest: compounds 1 and 2 (each within the scatter of the next); then compound 3.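

In this assay the aromatic carbon between two ring nitrogen atoms proves sensitive to substitution: amino in place of hydrogen gives a 15-fold higher number from compound 1 to compound 3 (1.18 log units; beyond the scatter) and so costs clear growth inhibition. Within the data shown here, no earlier pair of compounds differing in one place could show this. No measurement here accounts for the size of the step. Open, as far as these compounds go, is whether the loss is specific to amino or also follows from methylamino, hydroxyl or methyl on this carbon. Also open, from the compounds shown here alone, is whether the step would hold with the chloromethyl group placed as in compound 2.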